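Methoxyphenyl for methylpyrazolyl on the shared core: expectation

A few compounds are considered here, and "the series" means these few. Any claim that something is new, unique, unknown or untested is made for them only; others in the source may bear on it.

Measured so far:
compound 1 `CS(=O)(=O)c1ccc(-c2oc3ccccc3c(=O)c2-c2ccc(Cl)cc2)cc1`: < 5%
compound 2 `Cn1cc(-c2c(-c3ccc(S(C)(=O)=O)cc3)oc3ccccc3c2=O)cn1`: < 5%

In an assay on isolated protein for inhibition of prostaglandin G/H synthase 1 (Mus musculus), tested at 10 ug/mL (on this read-out lower numbers stand for less inhibition and higher numbers for more inhibition at the one concentration tested (going by the name of the read-out)), compound 1 gives < 5%, a limit of the assay. Compound 2 gives < 5% in this assay, likewise a limit. Among the measured compounds shown here, the only measured step, a step that the two limits leave unreadable from compound 1 to compound 2, cannot be read because of the limit of < 5% in this assay, at which 2 of the 2 values shown sit. Compound 3 `COc1ccc(-c2c(-c3ccc(S(C)(=O)=O)cc3)oc3ccccc3c2=O)cc1` carries the change (4-methoxyphenyl in place of 1-methyl-1H-pyrazol-4-yl on an aromatic carbon). No readable step bears on it, so compound 3 is expected to stay at the limit with a step that the limit leaves unreadable from compound 2 to compound 3 not beyond the scatter. The estimate for compound 3 in this assay is 3%, in the range 0% to 12%.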

Compound 3, a percentage reported as inhibition, at one concentration (the size of the read-out at that concentration, not a potency): < 5%
Compound 3: only a limit was reported; the forecaster's own chance of this, stated with the estimate: 75%; the middle value does not contradict the limit.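

Among the compounds shown here, no step among compound 1, compound 2 and compound 3 can be read in this assay, because all three sit at the same limit: the limit of < 5% in this assay, at which 3 of the 3 values shown sit. From the compounds shown here alone, whether 4-chlorophenyl, 1-methyl-1H-pyrazol-4-yl and 4-methoxyphenyl differ at all in this assay stays open.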